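A Fluorine Added to the Benzothiazole of Compound 2

The source may hold more compounds than are shown below. What is called first, only, known or untested is meant among the compounds shown, and "the series" means these compounds.

Of the compounds shown here, two of this set have been tested in a functional assay on MDA-MB-231 cells (Homo sapiens) for cytotoxicity, read by sulforhodamine B assay, with a stated time of 48 h; a lower number here means a stronger inhibitor of growth, a higher number a weaker inhibitor of growth. Compound 1 `Cc1ccc(-c2ccc([N+](=O)[O-])cc2)n1-c1ccc(-c2nc3ccccc3s2)cc1` gives 3900 nM in this assay, and compound 2 `COc1cc(-c2ccc(C)n2-c2ccc(-c3nc4ccccc4s3)cc2)cc(OC)c1OC` gives 3450 nM. Compound 2 holds the lower of the two numbers, yet its gap to compound 1 lies within the scatter, so the two values cannot be told apart. Compound 3 `COc1cc(-c2ccc(C)n2-c2ccc(-c3nc4ccc(F)cc4s3)cc2)cc(OC)c1OC` has not yet been measured. It differs from compound 2 in a single place: fluoro in place of hydrogen on an aromatic carbon. Among the measured compounds shown here, no measured pair in this set shows what such a change does, so there is no step to lean on. A small step is expected, with no direction that would stand out beyond the scatter, and the expected step is a 1.2-fold lower number from compound 2 to compound 3 (0.06 log units; within the scatter). Compound 3 is estimated to give about 3000 nM in this assay, with a range from 1200 nM to 8000 nM.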

Compound 3, concentration for 50% growth inhibition: 3000 nM
Beside the measured number, compound 3's estimate shows no gap at the digits printed; the range from low to high includes it.
By their numbers in this assay, from the lowest: compounds 3, 2 and 1 (each within the scatter of the next).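

Among the compounds shown here, the earlier compounds offered no pair differing in one place, so this is the first direct look at a change on the shared core: in this assay, replacing 1,3-benzothiazol-2-yl with 6-fluoro-1,3-benzothiazol-2-yl gives a 1.2-fold lower number from compound 2 to compound 3 (0.06 log units; within the scatter). The step lies within the scatter, so compound 2 and compound 3 cannot be told apart, and a single fluoro at this aromatic carbon leaves the growth-inhibition reading indistinguishable here. No measurement is available that would account for this result.

The compounds shown leave open whether this position would respond in the same way to a group other than fluoro, such as an amine, a carboxylic acid or a longer alkyl chain. They also leave open whether fluoro on another aromatic carbon of the core would give a step beyond the scatter.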